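The source may hold more compounds than are shown below. What is called first, only, known or untested is meant among the compounds shown, and "the series" means these compounds.

Of the compounds shown here, three have so far been measured in a functional assay on PC-12 cells (Rattus norvegicus) for cytotoxicity, read by MTT assay, with stated times of 3 h and 2 h, tested at 0.1 uM; on this read-out lower numbers stand for a weaker effect and higher numbers for a stronger effect at the one concentration tested. Compound 1 `O=C(CCCCC1CCSS1)NCc1cn(CCCOc2ccc3ccc(=O)oc3c2)nn1` gives 37.8%, compound 2 `O=C(CCCCC1CCSS1)NCc1cn(CCCOc2ccc3cc(-c4ccc(Cl)c(Cl)c4)c(=O)oc3c2)nn1` gives 38.1%, and compound 3 `O=C(CCCCC1CCSS1)NCc1cn(CCCCCOc2ccc3ccc(=O)oc3c2)nn1` gives 46.3%. Compound 3 thus carries the highest of the three numbers, but its distance from compound 2 and from compound 1 lies within the usual scatter of the read-out, so the three stand together rather than apart.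

Compound 4 `Cc1cc(=O)oc2cc(OCCCCCn3cc(CNC(=O)CCCCC4CCSS4)nn3)ccc12` differs from compound 3 in one place: methyl in place of hydrogen on an aromatic carbon. Among the compounds with values here, the one measured step that bears on this kind of change is the entry of a 3,4-dichlorophenyl group onto the shared core, which gave a number 0.3 percentage points higher from compound 1 to compound 2 (within the scatter). That change, a much larger group entering on the same ring system, moved the read-out not at all beyond the scatter. Within the data shown here, a single methyl in place of hydrogen is a smaller change still, and nothing measured so far suggests the core tolerates it any differently.

Compound 4 is therefore expected to come out close to compound 3, with a step of about a number 1.3 percentage points lower from compound 3 to compound 4 (within the scatter) in this assay. Compound 4 is estimated at 45%, within a range from 33% to 57%.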

Compound 4, a percentage reported as activity, at one concentration (the size of the read-out at that concentration, not a potency): 45.6%
For compound 4 the middle estimate is 0.6 percentage points below the measured one; low and high end bracket the measured number.
By their numbers in this assay, from the lowest: compounds 1, 2, 4 and 3 (each within the scatter of the next).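

In this assay, the carbon opposite the ring oxygen, which the earlier step between compound 1 and compound 2 did not touch, now has a measured result: methyl in place of hydrogen there gives a number 0.7 percentage points lower from compound 3 to compound 4 (within the scatter). This also extends the picture from the shorter linker of compound 1 and compound 2 to the longer linker shared by compound 3 and compound 4, since a substitution on an aromatic carbon of the core again gives a step within the scatter, and so neither of the two steps separates its pair of compounds. No measurement presented here offers an explanation for either result.

Methyl is a single heavy atom, so the compounds shown leave open whether an amine, a carboxylic acid or a larger group such as 3,4-dichlorophenyl at this same carbon would also stay within the scatter of compound 3. They also leave open how a longer chain in the linker would read, and, with only one concentration tested, how the compounds would compare across a range of concentrations.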